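The compounds below may be only part of what the source reports. "The series", "measured", "known", "first", "only" and "open" are said of these compounds alone.

Of the compounds shown here, three have been measured in an ADME assay on microsomes from liver (Rattus norvegicus) for metabolic stability, read by LC-MS, using NADPH, with a stated time of 10 min, tested at 0.5 uM; a lower number here means that less of the compound is left, a higher number that more of the compound is left. Compound 1 `COC(=O)Nc1cc(-c2cnc(OC[C@@](C)(N)CC(C)C)c(OC)c2)ccn1` gives 79%; compound 2 `COC(=O)Nc1cc(-c2cnc(OC[C@@](C)(N)CC(C)C)c(Cl)c2)ccn1` gives 73%, a value from which compound 1 differs only within the scatter, since a number 6 percentage points lower from compound 1 to compound 2 (within the scatter). Compound 3 `CC(=O)Nc1cc(-c2ccc(OC[C@@H](N)CC(C)C)c(C)c2)ccn1` gives 99%, a number beyond the scatter above compound 2. Compound 4 `COC(=O)Nc1cc(-c2ccc(OC[C@@](C)(N)CC(C)C)nc2)ccn1` differs from compound 2 by hydrogen in place of chloro on an aromatic carbon; the chloro leaves and a hydrogen enters. Within the data shown here, no measured step touches this change; the only step at the same position, chloro in place of methoxy, stayed within the scatter in this assay. The step from compound 2 to compound 4 is therefore expected to be a number 4 percentage points higher from compound 2 to compound 4 (within the scatter), none beyond the scatter. Compound 4 is estimated at 77%, with a range from 60% to 92%.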

Compound 4, percent of the compound remaining: 96%
Compound 4: middle estimate off by 19 percentage points, on the low side, outside the stated range (above it).
By their numbers in this assay, from the lowest: compounds 2 and 1 (each within the scatter of the next); then compounds 4 and 3 (each within the scatter of the next).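

At the carbon ortho to the (2-amino-2,4-dimethylpentyl)oxy group, exchanging methoxy for chloro had stayed within the scatter in this assay, so the position had seemed to tolerate change. Hydrogen there gives the first step beyond the scatter at this position, both from chloro (a number 23 percentage points higher from compound 2 to compound 4 (beyond the scatter)) and from methoxy (a number 17 percentage points higher from compound 1 to compound 4 (beyond the scatter)). Nothing at hand explains this difference. Open, from the compounds shown here alone, is whether fluoro, methyl or a nitrile on this carbon would give a number near those of the chloro and methoxy compounds or near that of compound 4.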